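Methoxy for nitro on the phenyl ring of compound 4

This account rests on a few compounds, and the source may have more. Where it says the series, first, only, none or still open, it means among the compounds named here.

Measured compounds in a functional assay on RD cells (Homo sapiens) for inhibition, read by MTT assay, with a stated time of 72 h; a lower number here means a stronger inhibitor, a higher number a weaker inhibitor:
compound 1 `CC(/C=N/N1C(=S)NC2C1N(C)C(=O)N2C)=C\c1ccccc1` gives 84000 nM;
compound 2 `CCN1C(=O)N(CC)C2C1N=C(SC)N2/N=C/C=C/c1ccccc1` gives 24000 nM;
compound 3 `CCN1C(=O)N(CC)C2C1N=C(SC)N2/N=C/C=C/c1ccccc1[N+](=O)[O-]` gives 41900 nM.

Compound 3 stands second highest of the three numbers. Among the measured compounds shown here, its nearest neighbour is compound 2, and the one step between them, a 1.7-fold higher number from compound 2 to compound 3 (0.24 log units; within the scatter), lies within the scatter. Compound 1, built on a different core, gives a number that sits within the scatter of compound 3 as well, so none of the three can be set apart from the others.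

Compound 4 `CCN1C(=O)N(CC)C2C1N=C(SC)N2/N=C/C=C/c1ccccc1OC` differs from compound 3 in one place: methoxy in place of nitro on an aromatic carbon. For the measured compounds named here, no measured step swaps one substituent for another at this aromatic carbon; the only step that touches the site, from compound 2 to compound 3, puts nitro in place of hydrogen and stays within the scatter. Nothing in the data shows that this position moves the number, so the expected step of a 1.2-fold lower number from compound 3 to compound 4 (0.08 log units; within the scatter) in this assay is none beyond the scatter. Compound 4 is therefore estimated at 35000 nM, with a range from 12000 nM to 100000 nM to cover the scatter and the lack of a direct precedent.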

Compound 4, half-maximal inhibitory concentration: 7970 nM
Compound 4: middle estimate off by 4.4-fold (0.64 log units), on the high side, and the stated range ends above it.
By their numbers in this assay, from the lowest: compound 4; then compounds 2, 3 and 1 (each within the scatter of the next, the first and the last beyond it).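

In this assay, replacing nitro with methoxy gives a 5.3-fold lower number from compound 3 to compound 4 (0.72 log units; beyond the scatter), and replacing hydrogen with methoxy gives a 3.0-fold lower number from compound 2 to compound 4 (0.48 log units; beyond the scatter), so this aromatic carbon, ortho to a large group, can move the number beyond the scatter, though only modestly. The earlier step, a 1.7-fold higher number from compound 2 to compound 3 (0.24 log units; within the scatter), had not shown this, and the site now appears to respond to which group it carries rather than simply to whether hydrogen has been replaced: nitro stays within the scatter of hydrogen, while methoxy does not. The data offer no measurement that accounts for this difference between methoxy and nitro.

The compounds shown leave open whether the lower number is particular to methoxy or would also appear with a hydroxyl, an ethoxy group or an amine on this carbon, and whether methoxy would have the same effect on another carbon of the phenyl ring. They also leave open whether the 2-methoxyphenyl change would carry over to the core of compound 1, which has a different core and a phenyl ring without a substituent.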